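This account rests on a few compounds, and the source may have more. Where it says the series, first, only, none or still open, it means among the compounds named here.

Compound 1 `CC[C@H]1O[C@H](COCc2ccccc2)[C@@H](OCc2ccccc2)[C@H](OCc2ccccc2)[C@H]1O` carries a hydroxyl on its core, and in a functional assay on HeLa cells (Homo sapiens) for antiproliferative activity, read by sulforhodamine B assay (on this read-out lower numbers stand for stronger inhibition of growth and higher numbers for weaker inhibition of growth), compound 1 gives > 50000 nM, a value that is a limit of the assay rather than a number. Compound 2 `CCC[C@H]1O[C@H](COCc2ccccc2)[C@@H](OCc2ccccc2)[C@H](OCc2ccccc2)[C@H]1O` differs from it by methyl in place of hydrogen on a saturated chain carbon, two bonds along the chain from a saturated ring carbon. In this assay compound 2 gives 17400 nM. Among the measured compounds shown here, the step of an at least 2.8-fold lower number from compound 1 to compound 2 (0.45 log units; beyond the scatter) therefore reaches out of the region where 2 of the 3 values so far sit (the limit of > 50000 nM in this assay, at which 2 of the 3 values shown sit).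

Compound 3 `CC[C@@H]1O[C@H](COCc2ccccc2)[C@@H](OCc2ccccc2)[C@H](OCc2ccccc2)C1=O` carries a carbonyl in its core instead; how its core differs from that of compound 1 is not broken down here. In this assay compound 3 gives > 50000 nM, which again is a limit of the assay.

Compound 4 `CCC[C@@H]1O[C@H](COCc2ccccc2)[C@@H](OCc2ccccc2)[C@H](OCc2ccccc2)C1=O` is related to compound 3 in the same way, by methyl in place of hydrogen on a saturated chain carbon, two bonds along the chain from a saturated ring carbon. The change sits at the same place in both pairs. For the measured compounds named here, for compound 4 the expectation rests on the single measured instance of this change, the step of an at least 2.8-fold lower number from compound 1 to compound 2 (0.45 log units; beyond the scatter) from the limit of compound 1, and on the limit of compound 3 (the limit of > 50000 nM in this assay, at which 2 of the 3 values shown sit), which leaves open how far below the limit compound 3 itself would stand. Compound 4 is thus expected to give about 22000 nM, with a range estimated from 7000 nM to 60000 nM. The step this estimate means for compound 4 is an at least 2.2-fold lower number from compound 3 to compound 4 (0.35 log units; beyond the scatter), and it remains likely that the assay reports only a limit.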

Compound 4, concentration for 50% growth inhibition: > 50000 nM
Compound 4 was reported as a limit; the forecaster's own chance of this, stated with the estimate: 45%; middle value at least 2.2-fold (0.35 log units) away from the limit.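

In this assay compound 4 gives > 50000 nM, which is a limit of the assay. No step can be read between compound 3 and compound 4, since both stand at the same limit: the limit of > 50000 nM in this assay, at which 3 of the 4 values shown sit.

The compounds shown leave open whether methyl in place of hydrogen changes the read-out in the carbonyl series, and where compound 3 and compound 4 themselves would stand.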